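A few compounds are considered here, and "the series" means these few. Any claim that something is new, unique, unknown or untested is made for them only; others in the source may bear on it.

Of the compounds shown here, three sharing one core have been tested in a functional assay on T47D cells (Homo sapiens) for inhibition, read by sulforhodamine B assay, with a stated time of 48 h, tested at 10 uM; a lower number here means less inhibition of growth, a higher number more inhibition of growth at the concentration tested. Compound 1 `C/C(=N\O)c1ccc(NC(=O)Cn2nc(-c3ccc(Cl)cc3)nc2N)cc1` gives 13.5% there. Compound 2 `COc1cc(-c2nc(N)n(CC(=O)Nc3ccc(/C(C)=N\O)cc3)n2)cc(OC)c1OC` gives 8.77%, and compound 3 `C/C(=N/O)c1ccc(NC(=O)Cn2nc(-c3ccccc3)nc2N)cc1` gives 23%. Compound 1 stands in the middle of these three numbers, but its gap to compound 2 and its gap to compound 3 both lie within the usual scatter of such measurements, so the three cannot be ranked against one another; all three sit at a low level of growth inhibition.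

Compound 4 `CC(=O)c1ccc(NC(=O)Cn2nc(-c3ccc(Cl)cc3)nc2N)cc1` has not yet been measured in this assay. It differs from compound 1 in one place: a group of 3 heavy atoms (2 carbon, 1 oxygen; no ring) in place of a group of 4 heavy atoms (2 carbon, 1 nitrogen, 1 oxygen; no ring), on an aromatic carbon The group that leaves carries a hydrogen-bond donor, the acetyl that enters carries none.

Among the compounds with values here, nothing measured here shows what such an exchange does, since no pair of measured compounds differs in that way. The three measured numbers all lie close together, which suggests that the change from compound 1 to compound 4 is expected to be small, a number 1.5 percentage points lower from compound 1 to compound 4 (within the scatter), with no clear direction beyond the scatter. Compound 4 is therefore estimated to give about 12% in this assay, most likely between 2% and 25%.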

Compound 4, percent growth inhibition at one concentration: 21.6%
Estimate against measurement, compound 4: 9.6 percentage points below; low and high end bracket the measured number.
By their numbers in this assay, from the lowest: compounds 2, 1, 4 and 3 (each within the scatter of the next, the first and the last beyond it).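

In this assay, within the data shown here, putting acetyl on this aromatic carbon, para to a large group, gives a number 8.1 percentage points higher from compound 1 to compound 4 (within the scatter), the first step that can be read at this position. The group that leaves carries a hydrogen-bond donor and acetyl carries none, yet this exchange cannot be told apart from the scatter, so for this one pair the donor is not needed to keep growth inhibition at this level. Nothing measured here gives a reason for the step.

The compounds shown leave open whether any group at this position can move growth inhibition clearly beyond the scatter. An amine, a carboxylic acid or a longer chain on the same aromatic carbon would test that, and this single pair cannot say how such groups would behave.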